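Methylamino added to the core of compound 1

The source may report more compounds than this note shows. Statements on the series, on what has been measured and on what is new or still open speak of the compounds shown alone.

Within the data shown here, in a physicochemical assay for lipophilicity, at pH 7.4 (a lower number here means a more polar compound, a higher number a more lipophilic compound), compound 1 (`Cc1n[nH]c(-c2ncc3cccnc3c2O)n1`) gives 0.73 and this is the only number so far, which makes it a single reference point and not a place in any ranking. Compound 2 (`O=C1CCCN1Cc1n[nH]c(-c2ncc3cccnc3c2O)n1`) also belongs to the series, but in this assay compound 2 stands as "not determined" (no result reported), so it offers no comparison.

Compound 3 (`CNc1ccnc2c(O)c(-c3nc(C)n[nH]3)ncc12`) differs from compound 1 in one place (methylamino in place of hydrogen on an aromatic carbon), with methylamino in place of hydrogen on an aromatic carbon, opposite the ring nitrogen. The rest of the core of compound 1 stays the same. Among the measured compounds shown here, no measured pair covers this change, so the expectation rests on the structural change alone and remains uncertain. In this assay a small downward step is expected, of a size not clearly beyond the usual scatter. The estimate amounts to an expected step of a number 0.23 log units lower from compound 1 to compound 3 (within the scatter) in this series. For compound 3 the expected value is 0.5 within an estimated range from -0.1 to 1.1 until a measurement is available.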

Compound 3, distribution coefficient: -0.2
Compound 3: the middle estimate sits 0.70 log units above what was measured, outside the stated range (below it).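

In this assay, among these compounds, methylamino in place of hydrogen on an aromatic carbon, opposite the ring nitrogen, gives a number 0.93 log units lower from compound 1 to compound 3 (beyond the scatter), the first measured step. The position therefore does not sit silent in this assay: one change on the core of compound 1 moves the read-out by more than repeat measurements would, and compound 3 at -0.2 falls on the other side of zero from compound 1 at 0.73. Nothing available on these compounds speaks to what lies behind the step.

Going by these compounds, whether the step belongs to methylamino specifically or would recur with another group at this place, such as a primary amine, dimethylamino or methoxy, remains open. On these data alone, a single pair also sets no pattern, so it is equally open whether the same change would give a step of similar size on another member of the series.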